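The source may report more compounds than this note shows. Statements on the series, on what has been measured and on what is new or still open speak of the compounds shown alone.

Compound 1 `Cn1c(N2CCCC2)c(C#N)c2c(N)ncnc21` is one of two compounds with a number in an assay on isolated protein for inhibition of Leucine-rich repeat serine/threonine-protein kinase 2 variant G2019S (Homo sapiens), read by TR-FRET and LanthaScreen, with stated times of 50 min and 30 min, in the presence of a further agent that is not named here (a lower number here means a stronger inhibitor, a higher number a weaker inhibitor), and in this assay compound 1 gives 1910 nM. Going by the values given here, its number is the higher of the two, yet the only neighbour, compound 2 `Cc1cn(C)nc1Nc1cc2c(c(N)n1)c(C#N)c(N1CCC[C@H]1C)n2C`, which in this assay gives 1290 nM, sits close enough that the two values fall within the scatter of one another, so the pair tells nothing beyond their two values. Among the compounds with values here, compound 2 differs from compound 1 in more than one place and no single step between them can be drawn.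

The unmeasured compound 3 `C[C@@H]1CCCN1c1c(C#N)c2c(N)ncnc2n1C` departs from compound 1 by a single change: methyl in place of hydrogen on a saturated ring carbon, next to the ring nitrogen and next to the ring atom that bears a large group. Within the data shown here, no measured pair shows this change on its own. With nothing more to go on than the two numbers above, the step is expected to be small and without a clear direction, a 1.5-fold lower number from compound 1 to compound 3 (0.17 log units; within the scatter), and compound 3 is therefore estimated at 1300 nM, within a range from 450 nM to 3800 nM.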

Compound 3, half-maximal inhibitory concentration: 11 nM
The estimate for compound 3 lay 120-fold (2.07 log units) above the measured number, outside the stated range (below it).
By their numbers in this assay, from the lowest: compound 3; then compounds 2 and 1 (each within the scatter of the next).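

The saturated ring carbon of the pyrrolidin-1-yl group in compound 1 proves to be a place where very little added matter counts for a great deal: in this assay, going from pyrrolidin-1-yl to 2-methylpyrrolidin-1-yl, which adds 1 heavy atom and 0 hydrogen-bond donors or acceptors, gives a 170-fold lower number from compound 1 to compound 3 (2.24 log units; beyond the scatter) on an otherwise unchanged structure. Compound 1 and compound 2 had given no sign of such sensitivity, as they differ in more than one place and their values lie within the scatter of each other. Nothing at hand accounts for why a single methyl has so large an effect here.

The compounds shown leave open whether a longer chain such as ethyl, or a hydroxymethyl group, on the same saturated ring carbon would keep this gain, and whether the methyl in the mirror-image arrangement would do the same. They also leave open whether this change would count for as much on a core other than that of compound 1.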